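The compounds below may be only part of what the source reports. "The series", "measured", "known", "first", "only" and "open" are said of these compounds alone.

Values measured so far in a functional assay on MCF7 cells (Homo sapiens) for antiproliferative activity; a higher number here means a weaker inhibitor, a lower number a stronger inhibitor

- Compound 1 `CC(C)=CCc1cc(C(=O)Nc2cc3ccc(OCC4CCCNC4)c(C)c3oc2=O)ccc1O` gives 790 nM
- Compound 2 `CCNCCCOc1ccc2cc(NC(=O)c3ccc(O)c(CC=C(C)C)c3)c(=O)oc2c1C` gives 980 nM
- Compound 3 `CCCNCCCOc1ccc2cc(NC(=O)c3ccc(O)c(CC=C(C)C)c3)c(=O)oc2c1C` gives 980 nM

Level with compound 2, compound 3 gives 980 nM in this assay and lies within the usual scatter of compound 1 as well, so the three cannot be ranked. Compound 4 `CCCN(CCC)CCCOc1ccc2cc(NC(=O)c3ccc(O)c(CC=C(C)C)c3)c(=O)oc2c1C` differs from compound 3 by propyl in place of hydrogen on an amine nitrogen in one place: propyl in place of hydrogen on an amine nitrogen.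

Within the data shown here, three measured steps bear on this change. The closest guide is methyl in place of hydrogen on a saturated chain carbon, two bonds along the chain from an amine nitrogen, which gave no change at the digits printed from compound 2 to compound 3 (within the scatter) as its result. Replacing piperidin-3-yl with the open chains gave a 1.2-fold higher number from compound 1 to compound 2 (0.09 log units; within the scatter) and a 1.2-fold higher number from compound 1 to compound 3 (0.09 log units; within the scatter) as the other two results. Among these three compounds, changes around the amine have not moved the number beyond the scatter. However, none of them has an amine nitrogen without a hydrogen, so this change is untested and the range must stay wide.

No step beyond the scatter is therefore expected in this assay and the estimated step is a 1.0-fold higher number from compound 3 to compound 4 (0.01 log units; within the scatter) as a result. The value expected for compound 4 is 1000 nM with an estimated range from 450 nM to 2200 nM as its limits.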

Compound 4, half-maximal inhibitory concentration: > 50000 nM
Compound 4: no number, only a limit (the forecaster's own chance of this, stated with the estimate: 3%); middle value at least 50-fold (1.69 log units) away from the limit.
By their numbers in this assay, from the lowest: compounds 1, 2 and 3 (each within the scatter of the next). At a limit, above all of these: compound 4.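

In this assay the reading for compound 4 is a limit of the assay and not a number: the limit of > 50000 nM in this assay, at which 1 of the 4 values shown sits. Putting propyl on the amine nitrogen leaves that nitrogen with no hydrogen and gives an at least 51-fold higher number from compound 3 to compound 4 (1.70 log units; beyond the scatter), and the same large break appears against the other two compounds as an at least 51-fold higher number from compound 2 to compound 4 (1.70 log units; beyond the scatter) and as an at least 63-fold higher number from compound 1 to compound 4 (1.80 log units; beyond the scatter). The earlier compounds all keep a hydrogen on this nitrogen and stay within the scatter of each other whether the amine is open-chain or sits in a piperidine ring, so this side of the molecule tolerates change only up to a point, and among the four compounds shown, compound 4 alone crosses it.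

The compounds shown cannot separate the loss of the hydrogen on the nitrogen from the presence of a second propyl chain, since both arrive in the same step. Among these compounds, a dimethylamino or methyl(propyl)amino group at the end of the same chain would pull these two apart, showing whether any fully substituted amine gives this result or only one carrying two propyl groups.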